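Piperidinyl versus cyclopropyl amides on the shared core

A few compounds are considered here, and "the series" means these few. Any claim that something is new, unique, unknown or untested is made for them only; others in the source may bear on it.

Measured so far:
compound 1 `Cn1cc(-c2nn(Cc3ccc(C(=O)N4CCCCC4)cc3)c(=O)c3ccccc23)cn1`: 65500 nM
compound 2 `Cc1noc(C)c1-c1nn(Cc2ccc(C(=O)NC3CC3)cc2)c(=O)c2ccccc12`: > 100000 nM

In a functional assay on HeLa cells (Homo sapiens) for antiproliferative activity, read by MTT assay, with a stated time of 72 h (on this read-out higher numbers stand for weaker inhibition and lower numbers for stronger inhibition), compound 1 gives 65500 nM. For compound 2 the entry is a limit of the assay, > 100000 nM, and not a measured number, so compound 2 stands at the limit of > 100000 nM in this assay, at which 1 of the 2 values shown sits, and its exact position on this scale is open. Within the data shown here, the two compounds differ in more than one place, so no single step between them can be read.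

Compound 3 `Cc1noc(C)c1-c1nn(Cc2ccc(C(=O)N3CCCCC3)cc2)c(=O)c2ccccc12` is not yet measured. It differs from compound 2 by piperidin-1-yl in place of cyclopropylamino on a carbonyl carbon. Among the measured compounds shown here, no measured pair shows this change on its own. For the measured compounds named here, the only guide is compound 1, which carries the same piperidinyl amide on a different heteroaryl group and gives 65500 nM, a value in the weak range. Compound 2, as said, stands at a limit of the assay. The step is therefore expected to be small, an at least 1.1-fold lower number from compound 2 to compound 3 (0.04 log units; that floor lies within the scatter), with a fair chance that compound 3 also ends in a limit. Compound 3 is estimated at 90000 nM, within 30000 nM to 300000 nM.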

Compound 3, half-maximal inhibitory concentration: > 100000 nM
Compound 3 ended at the assay's limit; the forecaster's own chance of this, stated with the estimate: 55%; at least 1.1-fold (0.04 log units) between middle value and limit.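

Compound 3 supplies a single-place comparison at the aromatic carbon with the piperidinyl amide held constant: in this assay, 3,5-dimethyl-1,2-oxazol-4-yl in place of 1-methyl-1H-pyrazol-4-yl gives an at least 1.5-fold higher number from compound 1 to compound 3 (0.18 log units; that floor lies within the scatter), so a real loss from this swap is possible but not established. The entry for compound 3 is a limit and not a number, and compound 3 now sits with compound 2 at that limit: the limit of > 100000 nM in this assay, at which 2 of the 3 values shown sit. The change on the carbonyl carbon, piperidin-1-yl in place of cyclopropylamino, cannot be read, so the 3,5-dimethyl-1,2-oxazol-4-yl pair gives no size or direction for this amide change.

Going by these compounds, it remains open how far compound 2 and compound 3 lie beyond the measurable range in this assay, and whether cyclopropylamino would behave differently on the carbonyl carbon with 1-methyl-1H-pyrazol-4-yl on the aromatic carbon. Also open, on these data alone, is whether a morpholin-4-yl group on the carbonyl carbon, or a carboxylic acid in place of the amide, would bring the series into a measurable range.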